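Cytotoxicity on the shared core, from compound 1 to compound 4

This account rests on a few compounds, and the source may have more. Where it says the series, first, only, none or still open, it means among the compounds named here.

Compound 1 `Cc1cc(C)c(Oc2cc(Nc3ccc(C#N)cc3)c(N)cc2[N+](=O)[O-])c(C)c1` is measured in an ADME assay on H9 cells (Homo sapiens) for cytotoxicity, read by XTT assay, with a stated time of 6 days (on this read-out lower numbers stand for higher toxicity in this test and higher numbers for lower toxicity in this test), at 32200 nM in this series. Of the two numbers shown, compound 1 holds the higher one, and compound 2 `Cc1cc(C=O)cc(C)c1Oc1ccc([N+](=O)[O-])c(Nc2ccc(C#N)cc2)c1` gives 14200 nM in the same test, a gap beyond the scatter. Compound 3 `Cc1cc(C)c(Oc2cc(Nc3ccc(C#N)cc3)c([N+](=O)[O-])cc2[N+](=O)[O-])c(C)c1` reaches only a limit of the assay, namely > 59800 nM in this assay. Going by the values given here, the single step between measured compounds that differ in one place, an at least 1.8-fold higher number from compound 1 to compound 3 (0.26 log units; that floor lies within the scatter) with nitro in place of amino on an aromatic carbon, is known only as a floor, and that floor rests on the limit of > 59800 nM in this assay, at which 1 of the 3 values shown sits, alone.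

Compound 4 `Cc1cc(C)c(Oc2ccc(N)c(Nc3ccc(C#N)cc3)c2)c(C)c1` differs from compound 1 by hydrogen in place of nitro on an aromatic carbon on the shared core. Among the compounds with values here, no measured step removes a nitro group; the one step that touches a nitro group adds one, with a size the limit leaves open. The step of a 1.3-fold lower number from compound 1 to compound 4 (0.11 log units; within the scatter) is therefore expected to stay within the scatter for compound 4. In this assay compound 4 is estimated at 25000 nM with a range from 9000 nM to 70000 nM around it.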

Compound 4, half-maximal cytotoxic concentration: 51000 nM
Beside the measured number, compound 4's estimate is 2.0-fold (0.31 log units) below it; measured number inside the range.
By their numbers in this assay, from the lowest: compound 2; then compounds 1 and 4 (each within the scatter of the next). At a limit, above all of these: compound 3.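

In this assay, the change of hydrogen in place of nitro on an aromatic carbon para to a (4-cyanophenyl)amino group gives a 1.6-fold higher number from compound 1 to compound 4 (0.20 log units; within the scatter). The earlier compounds shown here offered no measured step at this position, and this pair now shows that, with the amino group and the (4-cyanophenyl)amino group in place, the nitro group can leave without moving the number beyond the scatter. That reading rests on this single pair and reaches no further than compound 1 and compound 4.

On these data alone, whether a different group at this position, such as a methoxy group, a carboxylic acid or an aminomethyl group, would give a step beyond the scatter stays open. Compound 3 is known only at a limit of the assay, so the size of its nitro step also stays open: the limit of > 59800 nM in this assay, at which 1 of the 4 values shown sits.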